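A Methyl for a Nitro at the Limit

The source may hold more compounds than are shown below. What is called first, only, known or untested is meant among the compounds shown, and "the series" means these compounds.

In a functional assay on PC-3 cells (Homo sapiens) for cytotoxicity, read by MTT assay, with a stated time of 72 h (a higher number here means a weaker inhibitor, a lower number a stronger inhibitor), compound 2 `CNC(=O)c1cc(Oc2ccc(NC(=O)c3nccc(-c4ccc([N+](=O)[O-])cc4)n3)cc2)ccn1` gives > 100000 nM as a limit, not a number. Compound 1 `CNC(=O)c1cc(Oc2ccc(NC(=O)c3cc(-c4ccc(Br)cc4)ncn3)cc2)ccn1` gives > 100000 nM and this too is a limit. Among the compounds with values here, compound 3 `CNC(=O)c1cc(Oc2ccc(NC(=O)c3cc(-c4ccccc4)ncn3)cc2F)ccn1` gives 44300 nM as the only actual number so far. Compound 4 `CNC(=O)c1cc(Oc2ccc(NC(=O)c3nccc(-c4ccc(C)cc4)n3)cc2)ccn1` carries methyl in place of nitro on an aromatic carbon, para to a large group, and the full count is methyl in place of nitro on an aromatic carbon for this change. Within the data shown here, with compound 3 at 44300 nM as the sole number, little movement is expected. The estimated at least 1.2-fold lower number from compound 2 to compound 4 (0.09 log units; that floor lies within the scatter) is small, toward stronger inhibition, and may stay within the scatter. For compound 4 the estimate is 80000 nM with an expected range from 30000 nM to 200000 nM and a report of only a limit remains quite possible.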

Compound 4, half-maximal inhibitory concentration: 13100 nM
Estimate against measurement, compound 4: 6.1-fold (0.79 log units) above, and the stated range ends above it.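

In this assay, within the data shown here, the change from 4-nitrophenyl to 4-methylphenyl gives an at least 7.6-fold lower number from compound 2 to compound 4 (0.88 log units; beyond the scatter) as the first step that can be read between two compounds differing in one place. This position, on an aromatic carbon para to a large group, can therefore move the read-out beyond the scatter, which compound 1 and compound 3 could not show. Going by these compounds, the full size of the step stays open because compound 2 gives only a limit: the limit of > 100000 nM in this assay, at which 2 of the 4 values shown sit. On these data alone, whether an amine or a carboxylic acid at this position would behave like methyl or like nitro also stays open.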